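Hydroxy Added to the Shared Core: Expected Antiproliferative Potency

The source may report more compounds than this note shows. Statements on the series, on what has been measured and on what is new or still open speak of the compounds shown alone.

Measured compounds in a functional assay on HT-29 cells (Homo sapiens) for antiproliferative activity, read by MTT assay, with a stated time of 48 h; on this read-out higher numbers stand for weaker inhibition and lower numbers for stronger inhibition:
- compound 1, `Oc1ccc2cc1Oc1ccc(cc1)CCc1cccc(O)c1Oc1ccc(cc1)CC2`, gives 7570 nM
- compound 2, `Oc1ccc2cc1Oc1ccc(cc1)CCc1cccc(O)c1Oc1ccc(cc1O)CC2`, gives 17000 nM
- compound 3, `Oc1ccc2cc1Oc1ccc(cc1)CCc1ccc(O)c(c1)Oc1cccc(c1)CC2`, gives 7980 nM

Compounds 1 and 2 differ in a single place: hydroxy in place of hydrogen on an aromatic carbon. That change produced a 2.2-fold higher number from compound 1 to compound 2 (0.35 log units; beyond the scatter), so the added hydroxy went with a weaker inhibition in this assay.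

Compound 3 is built from the same atoms as compound 1, joined differently; the difference between the two cores is not broken down here. Their values in this assay lie within the usual scatter of each other, so no order between compound 1 and compound 3 can be read from them.

Compound 4, `Oc1ccc2cc1Oc1cccc(c1)CCc1ccc(O)c(c1)Oc1ccc(cc1O)CC2`, has not yet been measured. It differs from compound 3 as follows: hydroxy in place of hydrogen on an aromatic carbon. The place of this change is described in exactly the same words as the place of the change from compound 1 to compound 2, so it is the same change on a core that is joined differently.

Because the change from compound 1 to compound 2 gave a 2.2-fold higher number from compound 1 to compound 2 (0.35 log units; beyond the scatter), the same change from compound 3 to compound 4 is expected to give a step of a 2.0-fold higher number from compound 3 to compound 4 (0.30 log units; within the scatter) in this assay. This expectation rests on one pair only, and the cores differ in a way that is not broken down here, so a wide range is kept. Compound 4 is therefore estimated at 16000 nM, with a range from 8000 nM to 35000 nM.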

Compound 4, half-maximal inhibitory concentration: 12400 nM
Beside the measured number, compound 4's estimate is 1.3-fold (0.11 log units) above it; measured number inside the range.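

On the core of compound 3, hydroxy in place of hydrogen on an aromatic carbon gives in this assay a 1.6-fold higher number from compound 3 to compound 4 (0.19 log units; within the scatter), whereas on the core of compound 1 the same change gave a 2.2-fold higher number from compound 1 to compound 2 (0.35 log units; beyond the scatter), so only the first of these steps can be read as a weakening of inhibition. Set side by side, the two steps cannot be told apart, and so the change carries over from one core to the other as far as these numbers can show: the same change on two cores in this assay, a 2.2-fold higher number (0.35 log units; beyond the scatter) from compound 1 to compound 2 and a 1.6-fold higher number (0.19 log units; within the scatter) from compound 3 to compound 4, 1.4-fold (0.16 log units) apart, within the scatter of two such steps This does not show that the added hydroxy weakens inhibition on the core of compound 3 when that step is taken alone, and two pairs on two cores give no rule for any further core in the series.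

The compounds shown leave open how another group on the same aromatic carbon, such as methoxy, fluorine, an amine or a carboxylic acid, would compare with hydroxy or hydrogen on either core. They also leave open whether the agreement between the two steps would hold on cells other than those of this one assay.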